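The source may hold more compounds than are shown below. What is called first, only, known or untested is meant among the compounds shown, and "the series" means these compounds.

Measured so far:
- compound 1 `CCOc1ccc(COc2c(OC)cc(/C=C/C(=O)OCC(=O)Nc3ccccc3)cc2OC)cc1`: > 200000 nM
- compound 2 `COc1cc(/C=C/C(=O)OCC(=O)Nc2ccc(Cl)cc2)cc(OC)c1OCc1ccc(Cl)c(Cl)c1`: > 200000 nM

Both measured compounds were tested in a functional assay on K562 cells (Homo sapiens) for cytotoxicity, read by MTT assay, with a stated time of 72 h (on this read-out higher numbers stand for weaker inhibition and lower numbers for stronger inhibition), and in each case the assay reported only a limit rather than a number. For compound 1 the value of > 200000 nM is such a limit. For compound 2 the value of > 200000 nM is likewise a limit, so compound 2 cannot be placed against compound 1 at all; neither is known to be more or less potent than the other. Going by the values given here, the single piece of evidence that can be drawn from the two results is the limit of > 200000 nM in this assay, at which 2 of the 2 values shown sit.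

Compound 3 `CCOc1ccc(COc2c(OC)cc(/C=C/C(=O)OCC(=O)Nc3ccc(Cl)cc3)cc2OC)cc1` has not yet been measured in this assay. It differs from compound 2 in one place: 4-ethoxyphenyl in place of 3,4-dichlorophenyl on a saturated chain carbon bound to an oxygen on an aromatic ring. This brings into compound 3 the same 4-ethoxybenzyl group that compound 1 carries, while keeping the 4-chlorophenyl amide end of compound 2.

Among the compounds with values here, because compound 2 sits at > 200000 nM, a limit, no measured step can be computed, and any step from compound 2 to compound 3 in this assay can only be guessed. With both neighbours at the limit, compound 3 is expected to show no step beyond the scatter, that is a number no higher from compound 2 to compound 3 (the limit leaves the size open). Compound 3 is therefore estimated at 200000 nM, within a range from 50000 nM to 500000 nM.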

Compound 3, half-maximal inhibitory concentration: > 200000 nM
Compound 3: only a limit was reported; the forecaster's own chance of this, stated with the estimate: 80%; the middle value lies on the limit itself.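

In this assay compound 3 gives > 200000 nM, which is a limit and not a number. No step from compound 1 or compound 2 to compound 3 can be read, and all three share one result: the limit of > 200000 nM in this assay, at which 3 of the 3 values shown sit. The compounds shown leave open whether exchanging 3,4-dichlorobenzyl for 4-ethoxybenzyl, or adding the chloro, changes potency at all.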